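The compounds below may be only part of what the source reports. "The series", "measured", "known", "first", "only" and "open" are said of these compounds alone.

Of the compounds shown here, three sharing one core have been tested in a functional assay on BMDM cells (Mus musculus, strain C57BL/6) for inhibition, with a stated time of 2 days; on this read-out lower numbers stand for stronger inhibition and higher numbers for weaker inhibition. Compound 1 `CCOC(=O)c1sc(NC(=O)Cn2cc(-c3cccs3)nn2)nc1C` gives 20 nM. Compound 2 `Cc1csc(NC(=O)Cn2cc(-c3ccc([N+](=O)[O-])cc3)nn2)n1` gives 190 nM in this assay. Compound 3 `CCOC(=O)c1sc(NC(=O)Cn2cc(-c3ccc([N+](=O)[O-])cc3)nn2)nc1C` gives 1840 nM in this assay, the highest of the three numbers, so among these it is the weakest inhibitor, with both steps to it lying beyond the scatter. Those two steps are a 92-fold higher number from compound 1 to compound 3 (1.96 log units; beyond the scatter) and a 9.7-fold higher number from compound 2 to compound 3 (0.99 log units; beyond the scatter).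

Compound 4 `CCOC(=O)c1sc(NC(=O)Cn2cc(-c3ccc(C#N)cc3)nn2)nc1C` has not yet been measured. It differs from compound 3 in one place: cyano in place of nitro on an aromatic carbon. Neither measured step replaces one group with another on this phenyl ring, so neither speaks directly to the change. The step of a 92-fold higher number from compound 1 to compound 3 (1.96 log units; beyond the scatter) does show that the group at this end of the molecule can shift the number strongly, which leaves room for a sizeable move in either direction, while the other step concerns a different part of the core. Going by the values given here, with no closer precedent, the expectation is a modest shift toward stronger inhibition, carrying wide uncertainty. Compound 4 is therefore expected to give about 1000 nM in this assay, within a range from 200 nM to 5000 nM. That estimate corresponds to a step of a 1.8-fold lower number from compound 3 to compound 4 (0.26 log units; within the scatter).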

Compound 4, half-maximal inhibitory concentration: 310 nM
Compound 4: middle estimate off by 3.2-fold (0.51 log units), on the high side; measured number inside the range.
By their numbers in this assay, from the lowest: compound 1; then compounds 2 and 4 (each within the scatter of the next); then compound 3.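

In this assay, going by these compounds alone, the exchange of nitro for cyano on the phenyl ring, para to a large group, gives a 5.9-fold lower number from compound 3 to compound 4 (0.77 log units; beyond the scatter) and is the first direct look at a change of group on this ring. It shows that the number depends on the group carried by the phenyl ring as well as on the choice between that ring and thiophen-2-yl. Even so, the thiophen-2-yl ring keeps the lower number, with a 16-fold higher number from compound 1 to compound 4 (1.19 log units; beyond the scatter) against a 92-fold higher number from compound 1 to compound 3 (1.96 log units; beyond the scatter) for 4-nitrophenyl, so the exchange closes only part of that distance. Nothing measured here explains why the number moves with this exchange.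

Still open, going by these compounds, is how a plain phenyl ring, or one carrying a methoxy group, an amine or a carboxylic acid in the same place, would compare with 4-cyanophenyl and thiophen-2-yl. Also open, on these data alone, is whether ethoxycarbonyl in place of hydrogen would raise the number with 4-cyanophenyl in the way seen with 4-nitrophenyl in a 9.7-fold higher number from compound 2 to compound 3 (0.99 log units; beyond the scatter) on the shared core.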